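Swapping an Aromatic Group for an Anilino Group on a Shared Core

The source may hold more compounds than are shown below. What is called first, only, known or untested is meant among the compounds shown, and "the series" means these compounds.

Of the compounds shown here, three built on one shared core have been tested in an ADME assay on cells (Homo sapiens) for cytotoxicity, read by resazurin assay, with a stated time of 5 days; a lower number here means that less compound is tolerated, a higher number that more compound is tolerated. Compound 3 `O=S(=O)(Cc1nc(-c2ccc(F)nc2)c2sccc2n1)c1cccc(Cl)c1` carries a 6-fluoropyridin-3-yl group and is the only one of the three with a numerical reading; in this assay compound 3 gives 40000 nM. Compound 1 `O=S(=O)(Cc1nc(-c2cccs2)c2sccc2n1)c1cccc(Cl)c1`, with thiophen-2-yl at that position, reaches only the limit of the assay, > 50000 nM. Compound 2 `O=S(=O)(Cc1nc(-c2ccncc2)c2sccc2n1)c1cccc(Cl)c1`, with pyridin-4-yl there, likewise stops at the limit, > 50000 nM. Because two readings sit at the limit of > 50000 nM in this assay, at which 2 of the 3 values shown sit, the steps toward compound 3 are only floors: an at least 1.2-fold lower number from compound 1 to compound 3 (0.09 log units; that floor lies within the scatter) and an at least 1.2-fold lower number from compound 2 to compound 3 (0.09 log units; that floor lies within the scatter), and both floors lie within the scatter. The step that the two limits leave unreadable from compound 1 to compound 2 cannot be read at all.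

Compound 4 `COc1ccc(Nc2nc(CS(=O)(=O)c3cccc(Cl)c3)nc3ccsc23)cc1` has not been measured. Compared with compound 3 the change is (4-methoxyphenyl)amino in place of 6-fluoropyridin-3-yl on an aromatic carbon, placed on an aromatic carbon next to the ring nitrogen. Among the compounds with values here, the only steps that bear on it also exchange the group at this position, and none of them stands beyond the scatter. The step is therefore expected to be small: no change at the digits printed from compound 3 to compound 4 (within the scatter). Compound 4 is estimated at 40000 nM, with a range from 12000 nM to 100000 nM, and a reading at the limit is quite possible.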

Compound 4, half-maximal cytotoxic concentration: 60000 nM
Compound 4: middle estimate off by 1.5-fold (0.18 log units), on the low side; low and high end bracket the measured number.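

Until now, this position on the shared core had only held an aromatic ring attached directly, and each step swapped one such ring for another. Compound 4 joins its ring through a nitrogen instead and, unlike 6-fluoropyridin-3-yl, (4-methoxyphenyl)amino brings a hydrogen-bond donor, yet in this assay the result is a 1.5-fold higher number from compound 3 to compound 4 (0.18 log units; within the scatter), so this change of linkage shows no effect that can be told from the scatter. The steps from compound 1 and compound 2 to compound 4 cannot be read, because the readings for compound 1 and compound 2 are limits rather than numbers: the limit of > 50000 nM in this assay, at which 2 of the 4 values shown sit.

The compounds shown leave open whether this tolerance extends to groups without an aromatic ring at this position, such as morpholine, a simple alkyl amine or a carboxylic acid. They also leave open whether the methoxy group of compound 4 matters at all, which a plain anilino group or a chlorine in its place would help to settle.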